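A Third Aryl Group in a Cytotoxicity Series

The source may report more compounds than this note shows. Statements on the series, on what has been measured and on what is new or still open speak of the compounds shown alone.

Compound 1 `O=C(N/N=C/c1cccc(Br)c1)Nc1cc2c(Nc3ccc(F)c(Cl)c3)ncnc2cc1O[C@H]1CCOC1` gives 32300 nM
Compound 2 `O=C(N/N=C/c1ccc([N+](=O)[O-])cc1)Nc1cc2c(Nc3ccc(F)c(Cl)c3)ncnc2cc1O[C@H]1CCOC1` gives 35300 nM

Going by the values given here, in a functional assay on HepG2 cells (Homo sapiens) for cytotoxicity, read by MTT assay, with a stated time of 72 h (on this read-out lower numbers stand for stronger inhibition and higher numbers for weaker inhibition), compound 2 gives 35300 nM and stands within the scatter of compound 1, the only other compound measured. Compound 3 `O=C(N/N=C/c1ccc(F)cc1Cl)Nc1cc2c(Nc3ccc(F)c(Cl)c3)ncnc2cc1O[C@H]1CCOC1` differs from compound 2 by 2-chloro-4-fluorophenyl in place of 4-nitrophenyl on a carbon with a double bond to nitrogen with 2-chloro-4-fluorophenyl in place of 4-nitrophenyl on a carbon with a double bond to nitrogen. Among the compounds with values here, the one measured step that bears on this exchanged the group at that same place, and it is small: a 1.1-fold higher number from compound 1 to compound 2 (0.04 log units; within the scatter) with 4-nitrophenyl in place of 3-bromophenyl. Nothing beyond the scatter is therefore expected in this assay where a 1.1-fold lower number from compound 2 to compound 3 (0.03 log units; within the scatter) is the estimated step. For compound 3 the expected value is 33000 nM with an estimated range of 15000 nM to 65000 nM in this measurement.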

Compound 3, half-maximal inhibitory concentration: 26100 nM
The estimate for compound 3 lay 1.3-fold (0.10 log units) above the measured number, and the stated range covers the measured number.
By their numbers in this assay, from the lowest: compounds 3, 1 and 2 (each within the scatter of the next).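

In this assay the entry of 2-chloro-4-fluorophenyl gives a 1.4-fold lower number from compound 2 to compound 3 (0.13 log units; within the scatter) and a 1.2-fold lower number from compound 1 to compound 3 (0.09 log units; within the scatter) as its two steps. Going by these compounds alone, the place on a carbon with a double bond to nitrogen has thus now held three different substituted phenyl groups, one of them carrying two halogens, and no step among them leaves the scatter. Nothing measured here offers an explanation for this flat result. The compounds shown leave open whether a group of another kind at this place, such as an amine, a carboxylic acid or a longer alkyl chain, would move the number beyond the scatter.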